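Methyl for Isopropyl on a Second Core: Expected Inhibition

A few compounds are considered here, and "the series" means these few. Any claim that something is new, unique, unknown or untested is made for them only; others in the source may bear on it.

Measured compounds in a functional assay on the whole organism (Ear, strain ICR) for inhibition, with Mus musculus as the target, with stated times of 30 min and 2 h, at a dose of 10 umol/kg by the oral route; on this read-out higher numbers stand for more inhibition at the one dose given (going by the name of the read-out) and lower numbers for less inhibition:

Compound 1, `CC(C)[C@H](NCCC1OCC(C)(C)CO1)C(=O)N[C@H]1[C@@H](OCc2ccccc2)O[C@H](COCc2ccccc2)[C@@H](OCc2ccccc2)[C@@H]1OCc1ccccc1`, gives 86.2% in this assay.
Compound 2, `C[C@H](NCCC1OCC(C)(C)CO1)C(=O)N[C@H]1[C@@H](OCc2ccccc2)O[C@H](COCc2ccccc2)[C@@H](OCc2ccccc2)[C@@H]1OCc1ccccc1`, gives 90.3% in this assay.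
Compound 3, `CC(C)[C@H](NCCC1OCC(C)(C)CO1)C(=O)N[C@H]1C(O)O[C@H](CO)[C@@H](O)[C@@H]1O`, gives 85.1% in this assay.

Compound 1 and compound 2 share one core and differ in a single spot: methyl in place of isopropyl on a saturated chain carbon bound to an amine nitrogen and a carbonyl carbon. That swap produced a number 4.1 percentage points higher from compound 1 to compound 2 (within the scatter), so on this core the two numbers are indistinguishable within the usual scatter of the measurement.

Compound 3 carries a different core from compound 1; the difference between the two cores is not broken down here, and the two values are simply what they are, both sitting close together.

Compound 4, `C[C@H](NCCC1OCC(C)(C)CO1)C(=O)N[C@H]1C(O)O[C@H](CO)[C@@H](O)[C@@H]1O`, is built on the core of compound 3 and differs from it by exactly the change seen once already: methyl in place of isopropyl on a saturated chain carbon bound to an amine nitrogen and a carbonyl carbon. The surroundings of the change are described in the same words for both pairs, so this is the same change made a second time, on a second core.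

Among the compounds with values here, the only guide to what it will do is the earlier step. Since that step stayed within the scatter, the expectation is that compound 4 will again lie close to compound 3, with an estimated step of a number 2.9 percentage points higher from compound 3 to compound 4 (within the scatter), which rests on a number 4.1 percentage points higher from compound 1 to compound 2 (within the scatter). The estimate for compound 4 is therefore 88%, expected to fall between 77% and 96%.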

Compound 4, a percentage reported as inhibition, in the whole organism at one dose (the size of the read-out at that dose, not a potency): 86.8%
Compound 4: the middle estimate sits 1.2 percentage points above what was measured, and the stated range covers the measured number.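

In this assay, putting methyl in place of isopropyl on a saturated chain carbon bound to an amine nitrogen and a carbonyl carbon gives a number 1.7 percentage points higher from compound 3 to compound 4 (within the scatter) on the core of compound 3. Set beside the earlier step on the core of compound 1, this second step tells the same story, and the swap behaves alike on both cores as far as this measurement can tell: the same change on two cores in this assay, a number 4.1 percentage points higher (within the scatter) from compound 1 to compound 2 and a number 1.7 percentage points higher (within the scatter) from compound 3 to compound 4, 2.4 percentage points apart, within the scatter of two such steps. Within the data shown here, this supports only a modest statement: in these two pairs, at this one oral dose, the swap made no step large enough to read, but this does not show that methyl and isopropyl are interchangeable, as a percentage at a single dose is not a potency and a difference might appear at other doses.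

The compounds shown leave open whether the same calm holds for larger changes at this carbon, such as a longer chain, a phenyl ring or a carboxylic acid in place of isopropyl. They also leave open whether the agreement would extend to any core beyond these two, as two pairs are a small basis for a general rule.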